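The source may report more compounds than this note shows. Statements on the series, on what has been measured and on what is new or still open speak of the compounds shown alone.

Working notes on a set of acid-bearing antagonists run in a functional assay for antagonist activity at Oxoeicosanoid receptor 1 (Homo sapiens), read by fluorescence and calcium flux, with stated times of 2 min and 1 min; on this read-out lower numbers stand for stronger inhibition and higher numbers for weaker inhibition. Compound 3 `CC(CC(=O)O)CC(=O)c1c(CCCCc2ccccc2)n(C)c2ccc(Cl)cc12` gives 38 nM. Compound 1 `CC(CC(=O)O)CC(=O)c1c(CCCc2ccccc2)n(C)c2ccc(Cl)cc12` gives 223 nM. The change from compound 3 to compound 1 is phenyl in place of benzyl on a saturated chain carbon, three bonds along the chain from an aromatic carbon and the step it made is a 5.9-fold higher number from compound 3 to compound 1 (0.77 log units; beyond the scatter).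

Compound 2 `CC(CC(=O)O)CC(=O)n1c(CCCCCc2ccccc2)cc2ccc(Cl)cc21` gives 2.1 nM, the lowest number of the three measured. The difference between the core of compound 2 and the core of compound 3 is not broken down here.

Compound 4 `CC(CC(=O)O)CC(=O)n1c(CCCCc2ccccc2)cc2ccc(Cl)cc21` has not yet been measured in this assay. From compound 2 to compound 4 the change is phenyl in place of benzyl on a saturated chain carbon, four bonds along the chain from an aromatic carbon. This is the same kind of change as from compound 3 to compound 1, not the same one: there the place is three bonds along the chain from an aromatic carbon, here it is four bonds along the chain from an aromatic carbon. The change occurs twice among the compounds shown.

For the measured compounds named here, the step from compound 2 to compound 4 is expected to be a 3.8-fold higher number from compound 2 to compound 4 (0.58 log units; beyond the scatter), set beside the earlier 5.9-fold higher number from compound 3 to compound 1 (0.77 log units; beyond the scatter) and taken somewhat smaller, with only the one measured pair as the basis. Compound 4 is therefore expected to give about 8 nM, somewhere between 3 nM and 25 nM.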

Compound 4, half-maximal inhibitory concentration: 18 nM
Estimate against measurement, compound 4: 2.3-fold (0.35 log units) below; low and high end bracket the measured number.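

In this assay the new step is an 8.6-fold higher number from compound 2 to compound 4 (0.93 log units; beyond the scatter), and it matches the earlier step on the other core: the same change on two cores in this assay, a 5.9-fold higher number (0.77 log units; beyond the scatter) from compound 3 to compound 1 and an 8.6-fold higher number (0.93 log units; beyond the scatter) from compound 2 to compound 4, 1.5-fold (0.16 log units) apart, within the scatter of two such steps

On these two pairs, the change from benzyl to phenyl carries across the two cores in the same direction and at a similar size, so the data give no sign that the core of compound 2 and the core of compound 3 respond to it differently. This does not make a general rule: two pairs say nothing about a third core or about why the number moves, and no pair differing in one place links the two cores, so their own difference stays unresolved.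

For the compounds shown here, still open is whether a longer chain than the one in compound 2 would carry the number further in the same direction on that core. Also open, on these data alone, is how the series would respond to a tetrazole in place of the carboxylic acid, or to a fluorine in place of the chlorine.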